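This account rests on a few compounds, and the source may have more. Where it says the series, first, only, none or still open, it means among the compounds named here.

Working notes on the series. Compound 1 `O=C(Nc1cccc(-n2cc(-c3ccncc3)c(-c3ccc(Cl)c(O)c3)n2)c1)Nc1cccc(C(F)(F)F)c1` sets the shared core. In a functional assay on A498 cells (Homo sapiens) for inhibition, read by sulforhodamine B assay, with a stated time of 48 h (on this read-out lower numbers stand for stronger inhibition of growth and higher numbers for weaker inhibition of growth), compound 1 gives > 32500 nM, a limit of the assay, (the limit of > 32500 nM in this assay, at which 1 of the 3 values shown sits). Compound 2 `O=C(Nc1cccc(-n2cc(-c3ccncc3)c(-c3ccc(Cl)c(O)c3)n2)c1)Nc1ccc(Cl)c(Cl)c1` gives 3170 nM in this assay. Within the data shown here, the one single-point step measured, an at least 10-fold lower number from compound 1 to compound 2 (1.01 log units; beyond the scatter), concerns the urea terminus. Compound 3 `COc1cc(-c2nn(-c3cccc(NC(=O)Nc4ccc(Cl)c(C(F)(F)F)c4)c3)cc2-c2ccncc2)ccc1Cl` gives 6970 nM in this assay, the highest of the two numbers, compound 2 sitting lower. Compound 4 `O=C(Nc1cccc(-n2cc(-c3ccncc3)c(-c3ccc(Cl)c(O)c3)n2)c1)Nc1ccc(Cl)c(C(F)(F)F)c1` differs from compound 3 by hydrogen in place of methyl on an oxygen on an aromatic ring. Among the measured compounds shown here, no measured step covers that change, so only the values of compound 2 and compound 3 guide it. Compound 4 is expected at 4500 nM, within 1500 nM to 14000 nM. The expected step of a 1.5-fold lower number from compound 3 to compound 4 (0.19 log units; within the scatter) is thus modest and may fall within the scatter.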

Compound 4, concentration for total growth inhibition: 6900 nM
Compound 4: the middle estimate sits 1.5-fold (0.19 log units) below what was measured; measured number inside the range.
By their numbers in this assay, from the lowest: compound 2; then compounds 4 and 3 (each within the scatter of the next). At a limit, above all of these: compound 1.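

In this assay, the methoxy to hydroxy change on the 4-chloro-3-methoxyphenyl group does not separate the pair: a 1.0-fold lower number from compound 3 to compound 4 (0.00 log units; within the scatter). At the urea terminus, trifluoromethyl in place of chloro on an aromatic carbon gives a 2.2-fold higher number from compound 2 to compound 4 (0.34 log units; beyond the scatter). Chloro in place of hydrogen on an aromatic carbon gives an at least 4.7-fold lower number from compound 1 to compound 4 (0.67 log units; beyond the scatter), and the value of compound 1 is a limit: the limit of > 32500 nM in this assay, at which 1 of the 4 values shown sits.

On these data alone, what an amine or an ethoxy group would give in place of the hydroxy stays open. Also open, as far as these compounds go, is whether the methoxy to hydroxy result holds with the 3,4-dichlorophenyl terminus of compound 2.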